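A few compounds are considered here, and "the series" means these few. Any claim that something is new, unique, unknown or untested is made for them only; others in the source may bear on it.

Measured in a functional assay (aorta) for inhibition, with Rattus norvegicus as the target; a lower number here means that less compound is needed, a higher number that more compound is needed for the effect:
Compound 1 `O=C1C(Nc2ccc(F)cc2)=CC(=O)c2ncccc21`: 541 nM
Compound 2 `O=C1C(Nc2ccc(F)cc2F)=CC(=O)c2ncccc21`: 288 nM

For the measured compounds named here, only these two compounds have been measured so far, and compound 1 sits within the scatter of compound 2, its only neighbour on the scale. The next compound to be tested is compound 3 `O=C1C(Nc2ccc(Cl)cc2)=CC(=O)c2ncccc21`, which shares the core of compound 1 and carries chloro in place of fluoro on an aromatic carbon, para to a large group (chloro in place of fluoro on an aromatic carbon).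

Going by the values given here, no measured step makes this exchange. Among the compounds with values here, the one step available is a 1.9-fold lower number from compound 1 to compound 2 (0.27 log units; within the scatter), which comes from fluoro in place of hydrogen on an aromatic carbon. It is a different change, so it bears on the question only indirectly. It does show that one added halogen left the number in this assay within the scatter, though a single pair is thin evidence. No step beyond the scatter is therefore expected here, and no direction can be favoured. The expected step is a 1.2-fold lower number from compound 1 to compound 3 (0.08 log units; within the scatter). For compound 3 the estimated value is 450 nM, with an expected range from 170 nM to 1200 nM.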

Compound 3, half-maximal effective concentration: 178 nM
Beside the measured number, compound 3's estimate is 2.5-fold (0.40 log units) above it; the measured number falls inside the stated range.
By their numbers in this assay, from the lowest: compounds 3, 2 and 1 (each within the scatter of the next, the first and the last beyond it).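

In this assay, for the compounds shown here, chloro in place of fluoro on the aromatic carbon para to a large group gives a 3.0-fold lower number from compound 1 to compound 3 (0.48 log units; beyond the scatter), a modest change but the first step to lie beyond the scatter. Going by these compounds alone, the only earlier step, a 1.9-fold lower number from compound 1 to compound 2 (0.27 log units; within the scatter), changed a different place on the ring and stayed within the scatter, so this pair is the first sign that the number responds to the identity of the halogen at this position, though it rests on a single pair. No measurement is available that would account for this step.

What the compounds shown leave open is whether the number would keep falling with bromo at this position, and whether a halogen is needed there at all, which a methyl or methoxy group could test. Also open, as far as these compounds go, is whether chloro in place of fluoro at this position would give a step of similar size in the presence of the second fluoro of compound 2.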